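This account rests on a few compounds, and the source may have more. Where it says the series, first, only, none or still open, it means among the compounds named here.

Measured so far:
Compound 1 `C=CC(=O)N1CCC[C@@H](N2C(=O)N(Cc3ccccc3)Cc3cnc(Nc4ccc(N5CCN(C)CC5)cc4OC)nc32)C1` gives 142 ug/mL in a physicochemical assay for solubility, read by HPLC, in phosphate buffer, measured as thermodynamic solubility, with a stated time of 24 h, at pH 6.8; a higher number here means a more soluble compound, a lower number a less soluble compound.
Compound 2 `C=CC(=O)N1CC[C@H](N2C(=O)N(c3ccccc3)Cc3cnc(Nc4ccc(C5CCN(C)CC5)cc4)nc32)C1` gives 310 ug/mL in this assay.
Compound 3 `C=CC(=O)N1CC[C@H](N2C(=O)N(c3ccccc3)Cc3cnc(Nc4ccc(N5CCN(C)CC5)c(C(F)(F)F)c4)nc32)C1` gives 60.9 ug/mL in this assay.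

Among these three numbers compound 1 stands second highest. Compound 2 gives the higher number, and that gap lies beyond the usual scatter of repeated measurements; compound 3 gives the lower number, and that gap too lies beyond the scatter. Among the measured compounds shown here, compounds 2 and 3 differ from compound 1 in more than one place, so no pair here isolates a single change.

Compound 4 `C=CC(=O)N1CC[C@H](N2C(=O)N(Cc3ccccc3)Cc3cnc(Nc4ccc(N5CCN(C)CC5)cc4OC)nc32)C1` has not yet been measured in this assay. It differs from compound 1 in one place: 1-(vinylcarbonyl)pyrrolidin-3-yl in place of 1-(vinylcarbonyl)piperidin-3-yl on an amide-type nitrogen in a ring. The change removes one carbon from a ring while leaving the donor and acceptor count unchanged. For the measured compounds named here, no measured pair shows this step on its own, so the size of the step must be guessed. A small change of this kind is expected to give a step within the scatter, with a slight lean upward if anything.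

Compound 4 is therefore estimated at 170 ug/mL, with a likely range from 75 ug/mL to 380 ug/mL. The expected step is a 1.2-fold higher number from compound 1 to compound 4 (0.08 log units; within the scatter).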

Compound 4, solubility: 107 ug/mL
For compound 4 the middle estimate is 1.6-fold (0.20 log units) above the measured one; low and high end bracket the measured number.
By their numbers in this assay, from the lowest: compounds 3, 4 and 1 (each within the scatter of the next, the first and the last beyond it); then compound 2.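

In this assay, among the compounds shown here, putting 1-(vinylcarbonyl)pyrrolidin-3-yl in place of 1-(vinylcarbonyl)piperidin-3-yl on the amide-type nitrogen gives a 1.3-fold lower number from compound 1 to compound 4 (0.12 log units; within the scatter) and this is the only pair so far that isolates a single change. On the core of compound 1, the five-membered and the six-membered non-aromatic ring, each carrying the same vinylcarbonyl group, therefore cannot be told apart by this measurement. No measured property of either group is available to account for this result.

Still open, as far as these compounds go, is whether this holds for other groups at the same place, such as a four-membered azetidin-3-yl ring carrying the vinylcarbonyl group, or an open chain ending in the same group in place of a ring. Also open, from the compounds shown here alone, is whether the change would read the same with another group in place of the benzyl group: compound 2 and compound 3 carry the five-membered ring too, but each differs from compound 4 in more than one place, so neither can answer that.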